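Ester variation at the carbonyl oxygen of a thienyl core

The compounds below may be only part of what the source reports. "The series", "measured", "known", "first", "only" and "open" are said of these compounds alone.

Measured compounds:
compound 1, `CC1=C(C(=O)OCC(C)C)C(c2cccs2)NC(=O)N1`, 25%
compound 2, `CC1=C(C(=O)OC2CCCC2)C(c2cccs2)NC(=O)N1`, 9%

Among the measured compounds shown here, in an assay on membranes from CHO cells for displacement of a labelled ligand from adenosine receptor A1 (Homo sapiens), read by scintillation counting, with a stated time of 60 min, tested at 1 uM (on this read-out higher numbers stand for more inhibition at the one concentration tested (going by the name of the read-out) and lower numbers for less inhibition), compound 2 gives 9%, the lowest of the two numbers known; its nearest neighbour is compound 1, which in this assay gives 25%. For the measured compounds named here, the one measured step, a number 16 percentage points lower from compound 1 to compound 2 (beyond the scatter), is the step that bears on the present question, since it also changes the group on the oxygen next to the carbonyl group.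

Compound 3, `CC1=C(C(=O)OCC2CCC2)C(c2cccs2)NC(=O)N1`, has not yet been measured in this assay. It differs from compound 2 in that (cyclobutylmethyl in place of cyclopentyl on an oxygen next to a carbonyl group). The entering group carries a four-membered ring on a single carbon, so it stands somewhere between the isobutyl of compound 1 and the cyclopentyl of compound 2 in shape. Because a number 16 percentage points lower from compound 1 to compound 2 (beyond the scatter) went downward when the ring was attached directly to the oxygen, a partial return toward the value of compound 1 is expected, though it may not exceed the scatter. Compound 3 is therefore estimated to give 17%, within 4% to 32%, corresponding to an expected step of a number 8 percentage points higher from compound 2 to compound 3 (within the scatter).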

Compound 3, a percentage reported as inhibition, at one concentration (the size of the read-out at that concentration, not a potency): 39%
Beside the measured number, compound 3's estimate is 22 percentage points below it; the whole stated range lies below it.
By their numbers in this assay, from the lowest: compound 2; then compound 1; then compound 3.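

The step of a number 30 percentage points higher from compound 2 to compound 3 (beyond the scatter) in this assay shows that the number at this position is not set by the atoms of the group alone: cyclopentyl and cyclobutylmethyl have the same heavy-atom count, yet changing cyclopentyloxy to cyclobutylmethoxy on the shared core moves the inhibition beyond the scatter. The second step, a number 14 percentage points higher from compound 1 to compound 3 (beyond the scatter), comes from cyclobutyl in place of isopropyl on a saturated chain carbon bound to an oxygen next to a carbonyl group, and it shows that this position can give more inhibition than the isobutyl ester did, not merely recover what was lost with cyclopentyl. No measurement at hand accounts for either difference.

The compounds shown leave open whether cyclopropylmethyl or cyclopentylmethyl would continue this rise, and how a longer chain or an amine on the same oxygen would read. They also leave open whether the same order of the three esters would hold with another group in place of the thienyl ring.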